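A chloro step from a weak compound

The source may report more compounds than this note shows. Statements on the series, on what has been measured and on what is new or still open speak of the compounds shown alone.

Measured in a functional assay on ACHN cells (Homo sapiens); on this read-out lower numbers stand for stronger inhibition of growth and higher numbers for weaker inhibition of growth:
- Compound 1 `O=S(=O)(/C=C/c1ccc(F)cc1)Cc1ccc(Nc2ncnc3ccccc23)cc1`: 10 nM
- Compound 2 `O=S(=O)(/C=C/c1ccc(F)cc1F)Cc1ccc(Nc2ncnc3ccccc23)cc1`: 31000 nM

Compound 2 holds the higher of the two numbers. Compound 3 `O=S(=O)(/C=C/c1ccc(F)cc1F)Cc1ccc(Nc2ncnc3cc(Cl)ccc23)cc1` differs from it by one change, chloro in place of hydrogen on an aromatic carbon. Going by the values given here, only one measured step bears on this, a 3100-fold higher number from compound 1 to compound 2 (3.49 log units; beyond the scatter). It too replaced a hydrogen on an aromatic carbon, but with fluoro and elsewhere, so it shows that one small swap can matter here without predicting this one. Compound 2 gives 31000 nM, and a large move in this assay towards a lower number is expected, though its size is very uncertain. The expected step is a 7.8-fold lower number from compound 2 to compound 3 (0.89 log units; beyond the scatter). For compound 3 the estimated value is 4000 nM, with an expected range of 100 nM to 50000 nM.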

Compound 3, concentration for 50% growth inhibition: > 100000 nM
Compound 3: only a limit was reported; the forecaster's own chance of this, stated with the estimate: 15%; middle value at least 25-fold (1.39 log units) from the limit.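

For compound 3 the reading is only a limit of the assay, > 100000 nM, and not a number. Chloro in place of hydrogen on this aromatic carbon of the fused system gives an at least 3.2-fold higher number from compound 2 to compound 3 (0.50 log units; beyond the scatter), so a change at this position, which is the same in compounds 1 and 2, brings no recovery of growth inhibition to an already weak compound. The full size of this step cannot be read: the limit of > 100000 nM in this assay, at which 1 of the 3 values shown sits.

On these data alone, whether chloro here would act the same way on compound 1 remains open. So does the effect of an amine or a methoxy group at this position.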